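The source may report more compounds than this note shows. Statements on the series, on what has been measured and on what is new or still open speak of the compounds shown alone.

Compound 1 `CCOC(=O)C(C)C(O)(c1ccc(OC)c(OC)c1OC)c1cccc2ccccc12` — in a functional assay on HCT-116 cells (Homo sapiens) for inhibition, read by sulforhodamine B assay, with a stated time of 48 h (on this read-out higher numbers stand for weaker inhibition and lower numbers for stronger inhibition), compound 1 reaches only the limit of the assay, > 20000 nM.
Compound 2 `COc1ccc(C(O)(Cc2ccc(F)cc2)c2cccc3ccccc23)c(OC)c1OC` — in this assay compound 2 likewise reaches only the limit, > 20000 nM.
Compound 3 `COc1cc(COC(c2ccc(OC)c(OC)c2OC)c2cccc3ccccc23)cc(OC)c1` — in this assay compound 3 also reaches only the limit, > 20000 nM.

Compound 2 thus stands where every measured compound stands: at the limit of > 20000 nM in this assay, at which 3 of the 3 values shown sit, with no number of its own. Within the data shown here, the single step between measured compounds that differ in one place, a step that the two limits leave unreadable from compound 1 to compound 2, is a step from one limit to another and therefore tells nothing about its size or direction.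

Compound 4 `COc1ccc(C(O)(C/C=C\c2ccccc2)c2cccc3ccccc23)c(OC)c1OC` has not yet been measured in this assay. It differs from compound 2 by 2-phenylethenyl in place of 4-fluorophenyl on a saturated chain carbon, two bonds along the chain from two aromatic carbons and an oxygen on a saturated carbon. Among the measured compounds shown here, no measured step bears readably on this change, since the only one available is a step that the two limits leave unreadable from compound 1 to compound 2. The expectation for compound 4 is therefore carried by the common limit alone: the step from compound 2 is estimated as a number no higher from compound 2 to compound 4 (the limit leaves the size open), that is, no change that the numbers could show. Compound 4 is accordingly expected to give about 20000 nM, within 7000 nM to 60000 nM, most probably again as a limit rather than a number.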

Compound 4, half-maximal inhibitory concentration: > 20000 nM
Compound 4 was reported as a limit (the forecaster's own chance of this, stated with the estimate: 70%); the middle value lies on the limit itself.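

The steps joining compound 4 to compound 1 and to compound 2 run from one limit to another, and none of them can be read: the limit of > 20000 nM in this assay, at which 4 of the 4 values shown sit. The compounds shown leave open whether any change on the shared core alters inhibition in this assay, and by how much.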